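N-substituent changes on the shared core of compound 1

This account rests on a few compounds, and the source may have more. Where it says the series, first, only, none or still open, it means among the compounds named here.

Compound 1 `COc1ccc(-c2cc3c(OC)cc(OC)cc3n(C)c2=O)cc1` is the reference point of this small set. In a functional assay on U-87MG ATCC cells for cytotoxicity against U-87 MG (Homo sapiens), read by colorimetric assay and MTT assay (on this read-out higher numbers stand for weaker inhibition and lower numbers for stronger inhibition), compound 1 gives 10000 nM. Compound 2 `COc1ccc(-c2cc3c(OC)cc(OC)cc3n(CC#N)c2=O)cc1` gives 10000 nM in this assay, and compound 3 `COc1ccc(-c2cc3c(OC)cc(OC)cc3n(CC(=O)O)c2=O)cc1` gives 10000 nM. Compound 1 therefore stands level with compounds 2 and 3 at the digits shown: the step of no change at the digits printed from compound 1 to compound 2 (within the scatter) and the step of no change at the digits printed from compound 1 to compound 3 (within the scatter) both lie within the scatter, as does the step of no change at the digits printed from compound 2 to compound 3 (within the scatter).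

Compound 4 `COc1ccc(-c2cc3c(OC)cc(OC)cc3n(CCC(=O)OCc3ccccc3)c2=O)cc1` has not yet been measured in this assay. It differs from compound 1 by (benzyloxycarbonyl)methyl in place of hydrogen on a saturated chain carbon bound to an aromatic nitrogen. Within the data shown here, the steps that bear on this change are those at the same place: cyano in place of hydrogen and carboxy in place of hydrogen on the saturated chain carbon bound to the aromatic nitrogen, each of which left the read-out unchanged within the scatter. Among the measured compounds shown here, no step on a larger group at this place is available. The expectation for compound 4 is therefore a step of no change at the digits printed from compound 1 to compound 4 (within the scatter) that stays within the scatter, and compound 4 is estimated at 10000 nM, with a range from 3000 nM to 30000 nM.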

Compound 4, half-maximal inhibitory concentration: 10000 nM
The estimate for compound 4 equals the measured number at the digits printed; measured number inside the range.
By their numbers in this assay, from the lowest: compounds 1, 2, 3 and 4 (each within the scatter of the next).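

In this assay, (benzyloxycarbonyl)methyl gives no change at the digits printed from compound 1 to compound 4 (within the scatter), so the level read-out at this place now extends to an entering group of 11 heavy atoms carrying a six-membered aromatic ring of carbon only. Set against the earlier substituents, it gives no change at the digits printed from compound 3 to compound 4 (within the scatter) and no change at the digits printed from compound 2 to compound 4 (within the scatter), so neither carboxy, cyano nor this ester-bearing group separates from the others on this read-out. No measurement at hand bears on why the read-out stays level across these changes.

The compounds shown leave open whether an amine or a plain longer alkyl chain on this saturated chain carbon would shift the read-out. They also leave open whether hydroxy in place of methoxy on the shared core would do so, since every change shown lies at the one place.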